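Cytotoxicity notes: bromophenyl analogue of compound 3

The source may report more compounds than this note shows. Statements on the series, on what has been measured and on what is new or still open speak of the compounds shown alone.

Measured so far in an ADME assay on BJ cells (Homo sapiens) for cytotoxicity, read by CellTiter-Glo and resazurin assay, with a stated time of 72 h; a lower number here means that less compound is needed, a higher number that more compound is needed for the effect:
Compound 1 `CC(C)N(Cc1cccc(OCCCCCC(=O)O)c1)C(=O)c1ccc(-c2ccco2)cc1`: > 26000 nM, a limit of the assay.
Compound 2 `CC(C)N(Cc1cccc(OCCCCCC(=O)O)c1)C(=O)c1ccc(-c2cccc(F)c2)cc1`: > 26000 nM, a limit of the assay.
Compound 3 `CCOC(=O)CCCCCOc1cccc(CN(C(=O)c2ccc(-c3ccco3)cc2)C(C)C)c1`: > 26000 nM, a limit of the assay.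

All three readings sit at the limit of > 26000 nM in this assay, at which 3 of the 3 values shown sit, so none of the steps among them can be sized. The step that the two limits leave unreadable from compound 1 to compound 2 and the step that the two limits leave unreadable from compound 1 to compound 3 both stay unreadable for that reason. Compound 3 therefore stands only at the limit in this assay, with no number behind it.

Compound 4 `CCOC(=O)CCCCCOc1cccc(CN(C(=O)c2ccc(Br)cc2)C(C)C)c1` differs from compound 3 by bromo in place of furan-2-yl on an aromatic carbon. Among the measured compounds shown here, no measured step in this assay involves the same change, and the two steps that are on record give no readable size at all. There is thus no basis for expecting a shift beyond the scatter in this assay, and the expectation is that compound 4 will again fall at the limit. Compound 4 is estimated at 30000 nM, with a range from 13000 nM to 100000 nM, which means an expected step that the limit leaves unreadable from compound 3 to compound 4.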

Compound 4, half-maximal effective concentration: > 26000 nM
Compound 4: no number, only a limit; the forecaster's own chance of this, stated with the estimate: 85%; the middle value lies beyond the limit too.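

In this assay compound 4 gives > 26000 nM, which is a limit of the assay. The step from compound 3 to compound 4 therefore cannot be read: the limit of > 26000 nM in this assay, at which 4 of the 4 values shown sit.

The compounds shown leave open whether any change among them, including bromo in place of furan-2-yl, alters cytotoxicity at all.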